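This account rests on a few compounds, and the source may have more. Where it says the series, first, only, none or still open, it means among the compounds named here.

Measured so far:
compound 1 `CCOC(=O)c1cc(-c2cccc(OC(=O)NC3CCCCC3)c2)nn1-c1ccccc1` gives 539 nM in an assay on isolated protein for inhibition of Fatty-acid amide hydrolase 1 (Homo sapiens), read by fluorescence, with a stated time of 30 min; a lower number here means a stronger inhibitor, a higher number a weaker inhibitor;
compound 2 `CCOC(=O)c1cc(-c2cccc(OC(=O)NC3CCCCC3)c2)nn1-c1ccc(Cl)cc1` gives 353 nM in this assay.

Within the data shown here, compound 2 holds the lower of the two numbers in this assay, with compound 1 as its only neighbour; the gap between them, a 1.5-fold lower number from compound 1 to compound 2 (0.18 log units; within the scatter), is within the scatter, so no order can be read from the pair. Compound 3 `CCOC(=O)c1cc(-c2cccc(OC(=O)NC3CCCCC3)c2)nn1-c1ccc(OC)cc1` has not yet been measured. It differs from compound 2 in one place: methoxy in place of chloro on an aromatic carbon. Among the measured compounds shown here, of the measured steps only that from compound 1 to compound 2 bears on it, a substitution on the same aromatic carbon, and it was small, a 1.5-fold lower number from compound 1 to compound 2 (0.18 log units; within the scatter). Nothing in the data points to a large effect from a substituent at this carbon, so a small step in either direction, or none beyond the scatter, is expected. In this assay the expected step is a 1.3-fold higher number from compound 2 to compound 3 (0.11 log units; within the scatter). Compound 3 is estimated at 450 nM, within 180 nM to 1100 nM.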

Compound 3, half-maximal inhibitory concentration: 407 nM
The estimate for compound 3 lay 1.1-fold (0.04 log units) above the measured number, within the range that was stated.
By their numbers in this assay, from the lowest: compounds 2, 3 and 1 (each within the scatter of the next).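

In this assay, the para position of this aromatic ring now carries three different substituents, and the change from chloro to methoxy gives a 1.2-fold higher number from compound 2 to compound 3 (0.06 log units; within the scatter) while the change from hydrogen to methoxy gives a 1.3-fold lower number from compound 1 to compound 3 (0.12 log units; within the scatter) in the same series. Hydrogen, chloro and methoxy therefore cannot be told apart here, even though methoxy brings 1 hydrogen-bond acceptor and chloro brings 0, which the earlier pair of compounds could not show. No measurement is available that would explain this flat result.

The compounds shown leave open whether an amine, a carboxylic acid or a longer chain such as butoxy on this same carbon would give a step beyond the scatter. They also leave open whether chloro or methoxy would behave the same way on the other carbons of this ring.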